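Pentan-3-ylamino in place of cyclopropyl(propyl)amino on the shared core

The compounds below may be only part of what the source reports. "The series", "measured", "known", "first", "only" and "open" are said of these compounds alone.

Of the compounds shown here, three on one core have been measured in an assay on cell membranes for displacement of a labelled ligand from corticotropin-releasing factor receptor 1 (Rattus norvegicus); a lower number here means a stronger inhibitor, a higher number a weaker inhibitor. Compound 1 `CCC1CCCCN1c1nc(C)nc2c(-c3c(C)cc(OC)cc3OC)c(C)nn12` gives 3.26 nM, compound 2 `CCCC(C)Nc1nc(C)nc2c(-c3c(C)cc(OC)cc3OC)c(C)nn12` gives 2.14 nM, and compound 3 `CCCN(c1nc(C)nc2c(-c3c(C)cc(OC)cc3OC)c(C)nn12)C1CC1` gives 1.48 nM. Compound 3 stands apart from compound 1 by a 2.2-fold lower number from compound 1 to compound 3 (0.34 log units; beyond the scatter), while a 1.4-fold lower number from compound 2 to compound 3 (0.16 log units; within the scatter) leaves compound 3 and compound 2 indistinguishable. Compound 4 `CCC(CC)Nc1nc(C)nc2c(-c3c(C)cc(OC)cc3OC)c(C)nn12` differs from compound 3 by (pentan-3-yl)amino in place of cyclopropyl(propyl)amino on an aromatic carbon. The step most like this one, a 1.4-fold lower number from compound 2 to compound 3 (0.16 log units; within the scatter), went from a branched secondary amino group to cyclopropyl(propyl)amino without leaving the scatter, and a 1.5-fold lower number from compound 1 to compound 2 (0.18 log units; within the scatter) also stayed within it. The return to a branched secondary amino group is therefore expected to move this assay little: compound 4 is estimated at 2.2 nM, between 1 nM and 5 nM, a step of a 1.5-fold higher number from compound 3 to compound 4 (0.17 log units; within the scatter) that is expected to stay within the scatter.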

Compound 4, half-maximal inhibitory concentration: 5 nM
For compound 4 the middle estimate is 2.3-fold (0.36 log units) below the measured one; the measured number falls inside the stated range.
By their numbers in this assay, from the lowest: compounds 3, 2, 1 and 4 (each within the scatter of the next, the first and the last beyond it).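

In this assay, for the compounds shown here, a 3.4-fold higher number from compound 3 to compound 4 (0.53 log units; beyond the scatter) and a 2.3-fold higher number from compound 2 to compound 4 (0.37 log units; beyond the scatter) show that this position can separate two open-chain groups on the amino nitrogen, pentan-3-yl and 1-methylbutyl, a difference the earlier compounds did not reveal. Yet a 1.5-fold higher number from compound 1 to compound 4 (0.19 log units; within the scatter) leaves compound 4 indistinguishable from compound 1, which carries 2-ethylpiperidin-1-yl. On these data alone, whether a cyclobutyl(propyl)amino or a (dicyclopropylmethyl)amino group would keep the number of compound 3 remains open. No available measurement bears on why these groups differ.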